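Pyrazinyl in place of carbamoyl on a pyridyl guanidine

The source may report more compounds than this note shows. Statements on the series, on what has been measured and on what is new or still open speak of the compounds shown alone.

Measured so far:
compound 1, `N#CNC(=N)Nc1cccnc1`: 50 mg/kg
compound 2, `CCC(C)(C)N/C(=N\C(N)=O)Nc1cccnc1`: > 50 mg/kg

In a functional assay on the whole organism (blood, strain Wistar-Okamoto) with Rattus norvegicus as the target, with a stated time of 5 days (a higher number here means that more compound is needed for the effect, a lower number that less compound is needed), compound 1 gives 50 mg/kg. Going by these compounds, for compound 2 this assay yields only a limit, > 50 mg/kg, so its true minimum effective dose is unknown; the limit reads (the limit of > 50 mg/kg in this assay, at which 1 of the 2 values shown sits). Compound 3, `CCC(C)(C)N/C(=N\c1cnccn1)Nc1cccnc1`, differs from compound 2 at one place: pyrazin-2-yl in place of carbamoyl on a double-bonded nitrogen. Within the data shown here, no measured step exists to calibrate this change, and the starting point is itself a limit, so the direction of the step is uncertain. The author expects the step from compound 2 to compound 3 to come out as an at least 1.6-fold lower number from compound 2 to compound 3 (0.22 log units; that floor lies within the scatter), toward a lower dose, though a result that is again only a limit cannot be ruled out. For compound 3 in this assay the author estimates 30 mg/kg, within a range from 10 mg/kg to 100 mg/kg.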

Compound 3, minimum effective dose: 25 mg/kg
Compound 3: middle estimate off by 1.2-fold (0.08 log units), on the high side; the measured number falls inside the stated range.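

Among these compounds, on the double-bonded nitrogen, pyrazin-2-yl in place of carbamoyl gives the first step that can be read in this assay, and that step is an at least 2.0-fold lower number from compound 2 to compound 3 (0.30 log units; that floor lies within the scatter). Compound 2 stands only as a limit, so the step has a floor and no upper end: the limit of > 50 mg/kg in this assay, at which 1 of the 3 values shown sits. Compound 3 gives 25 mg/kg, a real minimum effective dose, which shows that this position can carry a six-membered aromatic ring with hetero atoms and still give a measured dose in the whole animal.

Going by these compounds, how large the step truly is stays open, and the floor alone does not take it beyond the scatter. Also open, on these data alone, is whether phenyl, pyridin-2-yl or a simple acetyl group on that nitrogen would read like pyrazin-2-yl or like carbamoyl.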